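A Methoxymethoxymethyl Group in Place of Vinyl

A few compounds are considered here, and "the series" means these few. Any claim that something is new, unique, unknown or untested is made for them only; others in the source may bear on it.

Three compounds from this series carry measured values in a functional assay on SK-OV-3 cells (Homo sapiens) for cytotoxicity, read by MTT assay, with a stated time of 48 h; on this read-out higher numbers stand for weaker inhibition and lower numbers for stronger inhibition. Compound 1 `C=CCn1c(-c2ccc(OC)cc2C=C)cc2ccccc2c1=O` gives 43800 nM, the lowest of the three numbers shown. For the measured compounds named here, compound 2 `C=CCn1c(-c2cc(OC)c(OC)cc2C=O)cc2ccccc2c1=O` gives 85500 nM, and compound 3 `COCOCc1cc(OC)c(OC)cc1-c1cc2ccccc2c(=O)[nH]1` gives 87700 nM; both of these lie within the scatter of the value of compound 1, so no order among the three can be claimed, and no single measured step between them exists on which a trend could rest.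

Compound 4 `C=CCn1c(-c2ccc(OC)cc2COCOC)cc2ccccc2c1=O` is not yet measured. It differs from compound 1 in one place: (methoxymethoxy)methyl in place of vinyl on an aromatic carbon. The same (methoxymethoxy)methyl group is present in compound 3, whose value of 87700 nM sits in the same range as compound 1, though compound 3 also differs elsewhere, so this is only a loose guide. The step from compound 1 to compound 4 is expected to be small, at most a modest weakening, and likely within the scatter, as a 1.4-fold higher number from compound 1 to compound 4 (0.14 log units; within the scatter). Compound 4 is therefore estimated at 60000 nM, with a range from 25000 nM to 150000 nM.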

Compound 4, half-maximal inhibitory concentration: > 100000 nM
Compound 4: a limit, no number; the forecaster's own chance of this, stated with the estimate: 15%; at least 1.6-fold (0.22 log units) between middle value and limit.
By their numbers in this assay, from the lowest: compounds 1, 2 and 3 (each within the scatter of the next). At a limit, above all of these: compound 4.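

At this aromatic carbon, ortho to a large group and meta to a methoxy group, the change of vinyl to (methoxymethoxy)methyl is not neutral: in this assay it gives an at least 2.2-fold higher number from compound 1 to compound 4 (0.35 log units; beyond the scatter). This is the only measured step in one place among the compounds shown, so it gives this position a reading that the numbers of the earlier compounds could not provide. Compound 4 carries a limit of the assay and not a number, so the true size of the step stays unknown: the limit of > 100000 nM in this assay, at which 1 of the 4 values shown sits.

The compounds shown do not separate the departure of the vinyl double bond from the entry of the two oxygen atoms as the source of the step. They also leave open how a hydroxymethyl group, an aminomethyl group or a plain propyl chain would read at this carbon.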